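Butyl to hexyl on the amino chain: cytotoxicity notes

A few compounds are considered here, and "the series" means these few. Any claim that something is new, unique, unknown or untested is made for them only; others in the source may bear on it.

Compound 1 `CCCCNc1cnc(C(=O)NCc2ccccc2)cn1` and compound 2 `CCCCNc1nccnc1C(=O)NCc1ccccc1` carry the same groups, placed differently on the shared core. In an ADME assay on Vero cells (Chlorocebus sabaeus) for cytotoxicity, read by microscopy, with a stated time of 6 days (on this read-out lower numbers stand for higher toxicity in this test and higher numbers for lower toxicity in this test), compound 1 gives only a limit, > 100000 nM. In this assay compound 2 likewise gives only a limit, > 100000 nM, so compound 2 stands where every value shown stands, at the limit of > 100000 nM in this assay, at which 2 of the 2 values shown sit. Compound 3 `CCCCCCNc1nccnc1C(=O)NCc1ccccc1` carries ethyl in place of hydrogen on a saturated chain carbon, four bonds along the chain from a nitrogen on an aromatic ring. Within the data shown here, no measured step covers a change of this kind, so in this assay no step beyond the usual scatter is expected, and the limit is likely to recur. Compound 3 is estimated at 100000 nM, within 30000 nM to 200000 nM, which means an expected step of a number no higher from compound 2 to compound 3 (the limit leaves the size open).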

Compound 3, minimum cytotoxic concentration: > 100000 nM
Compound 3 gave a limit, no number (the forecaster's own chance of this, stated with the estimate: 65%); the middle value sits exactly at the limit.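

Among these compounds, compound 2 and compound 3 both give only limits, so no step between them can be read. The compounds shown leave open whether ethyl in place of hydrogen changes cytotoxicity, and at what concentration any of them would show it.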